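Shorter anilinomethyl amide tested against a benzyl-ethyl lead

The source may report more compounds than this note shows. Statements on the series, on what has been measured and on what is new or still open speak of the compounds shown alone.

Measured compounds:
Compound 1 `CC(C)C[C@H](N)c1cc(C(F)(F)F)ccc1N1CCN(C(=O)CC(C)C(=O)c2ccc(Cl)cc2)CC1`: 1100 nM
Compound 2 `CC(C)C[C@H](N)c1cc(C(F)(F)F)ccc1N1CCN(C(=O)COc2ccc([N+](=O)[O-])cc2)CC1`: 3100 nM
Compound 3 `Cc1cc(CC(C)C(=O)N2CCN(c3ccc(C(F)(F)F)cc3[C@@H](N)CC(C)C)CC2)ccc1Cl`: 71 nM

In an assay on HEK293 cells for displacement of a labelled ligand from Melanocortin receptor 4 (Homo sapiens) (on this read-out higher numbers stand for weaker inhibition and lower numbers for stronger inhibition), compound 3 gives 71 nM and holds the lowest number of the three, with compound 1 next at 1100 nM and compound 2 furthest at 3100 nM. The steps leading to compound 3 were both large: a 15-fold lower number from compound 1 to compound 3 (1.19 log units; beyond the scatter) and a 44-fold lower number from compound 2 to compound 3 (1.64 log units; beyond the scatter).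

Compound 4 `CC(C)C[C@H](N)c1cc(C(F)(F)F)ccc1N1CCN(C(=O)CNc2ccccc2)CC1` carries a different group on the same carbonyl carbon: anilinomethyl in place of 1-(4-chloro-3-methylbenzyl)ethyl on a carbonyl carbon. Among the measured compounds shown here, of the measured steps, the closest in kind is the one from compound 3 back toward compound 2, since both compound 2 and compound 4 place a single chain carbon between the carbonyl and a heteroatom bearing a phenyl ring, and that step was a 44-fold lower number from compound 2 to compound 3 (1.64 log units; beyond the scatter) in the reverse direction. The step of a 2.8-fold higher number from compound 1 to compound 2 (0.45 log units; beyond the scatter) shows that such heteroatom-linked phenyl groups sat at the weaker end of this set.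

Compound 4 is therefore expected to give a large step back toward weaker binding, roughly a 28-fold higher number from compound 3 to compound 4 (1.45 log units; beyond the scatter), with an estimate in this assay of 2000 nM and a range of 500 nM to 8000 nM.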

Compound 4, inhibition constant: 3600 nM
Beside the measured number, compound 4's estimate is 1.8-fold (0.26 log units) below it; the measured number falls inside the stated range.
By their numbers in this assay, from the lowest: compound 3; then compound 1; then compounds 2 and 4 (each within the scatter of the next).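

On the carbonyl carbon, in this assay, anilinomethyl in place of 1-(4-chloro-3-methylbenzyl)ethyl gives up nearly all of the lead's binding (a 51-fold higher number from compound 3 to compound 4 (1.71 log units; beyond the scatter)). The nitrogen-linked unsubstituted phenyl and the oxygen-linked 4-nitrophenyl on the saturated chain carbon cannot be told apart (a 1.2-fold higher number from compound 2 to compound 4 (0.06 log units; within the scatter)), so swapping the linking atom and removing the nitro group together leave no measurable trace. Anilino in place of 1-((4-chlorophenyl)carbonyl)ethyl gives a modest step (a 3.3-fold higher number from compound 1 to compound 4 (0.51 log units; beyond the scatter)), in the same direction as the one seen with 4-nitrophenoxy.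

Nothing given here accounts for any of these differences. Going by these compounds, it remains open how a 4-chloroanilinomethyl group or a longer chain such as anilinoethyl would read, and so whether the ring chlorine or the chain carries the gain.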